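A Hydroxy Group Added to a Weakly Active Acid

The source may report more compounds than this note shows. Statements on the series, on what has been measured and on what is new or still open speak of the compounds shown alone.

Compound 2 `COc1ccc(Cn2c(C(=O)O)c(CNCc3cccc(OC)c3)c3ccccc32)cc1` gives 52900 nM in a functional assay on Bel-7402 cells (Homo sapiens) for antiproliferative activity, read by MTT assay, with a stated time of 72 h (on this read-out lower numbers stand for stronger inhibition and higher numbers for weaker inhibition), the higher of the two numbers recorded so far. Compound 1 `COc1cccc(CNCc2c(C(=O)O)n(Cc3ccccc3)c3cc(C(C)C)ccc23)c1` stands well apart from it at 5900 nM, a gap beyond the usual scatter. The next compound, compound 3 `COc1ccc(Cn2c(C(=O)O)c(CNCc3ccc(O)c(OC)c3)c3ccccc32)cc1`, carries hydroxy in place of hydrogen on an aromatic carbon. For the measured compounds named here, no pair of measured compounds isolates such a change, so no measured step speaks to it. For compound 3 the expected step is a 1.3-fold lower number from compound 2 to compound 3 (0.12 log units; within the scatter), a small move toward a lower number that stays within the scatter. Compound 3 is therefore estimated at 40000 nM, with a range from 12000 nM to 130000 nM.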

Compound 3, half-maximal inhibitory concentration: > 50000 nM
Compound 3 was reported as a limit (the forecaster's own chance of this, stated with the estimate: 10%); middle value at least 1.2-fold (0.09 log units) away from the limit.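

No step from compound 2 to compound 3 can be read, because compound 3 is reported only as a limit: the limit of > 50000 nM in this assay, at which 1 of the 3 values shown sits.

Going by these compounds, whether the added hydroxy changes the antiproliferative read-out in either direction stays open.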